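Trimethylphenyl replacing dinitrophenyl on the triazole nitrogen

The compounds below may be only part of what the source reports. "The series", "measured", "known", "first", "only" and "open" are said of these compounds alone.

Of the compounds shown here, two sharing one core have been measured in a functional assay on HCT-116 cells (Homo sapiens) for antiproliferative activity, read by MTT assay, with a stated time of 48 h; on this read-out lower numbers stand for stronger inhibition and higher numbers for weaker inhibition. Compound 1 `N#CC1=C(N)Oc2c(N)cc3nc4ccccc4nc3c2C12C(=O)N(Cc1cnnn1-c1ccccc1Cl)c1ccccc12` gives a value that is a limit of this assay rather than a number, > 50000 nM. Among the compounds with values here, compound 2 `N#CC1=C(N)Oc2c(N)cc3nc4ccccc4nc3c2C12C(=O)N(Cc1cnnn1-c1ccc([N+](=O)[O-])cc1[N+](=O)[O-])c1ccccc12` gives 23900 nM in this assay, the only number among the two values shown. The step of an at least 2.0-fold lower number from compound 1 to compound 2 (0.32 log units; beyond the scatter) is at least modest, its lower bound set by the limit of > 50000 nM in this assay, at which 1 of the 2 values shown sits. Compound 3 `Cc1cc(C)c(-n2nncc2CN2C(=O)C3(C(C#N)=C(N)Oc4c(N)cc5nc6ccccc6nc5c43)c3ccccc32)c(C)c1` carries the change (2,4,6-trimethylphenyl in place of 2,4-dinitrophenyl on an aromatic nitrogen). Within the data shown here, the one measured step bears only loosely on it: it exchanges a 2-chlorophenyl for a 2,4-dinitrophenyl, whereas here the 2,4-dinitrophenyl gives way to a 2,4,6-trimethylphenyl, a group no measured step covers. Compound 3 is therefore expected to give roughly 40000 nM in this assay, within a range from 15000 nM to 100000 nM, with a fair chance of returning only a limit. That estimate amounts to an expected 1.7-fold higher number from compound 2 to compound 3 (0.22 log units; within the scatter) in this assay.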

Compound 3, half-maximal inhibitory concentration: > 50000 nM
Compound 3 gave a limit, no number (the forecaster's own chance of this, stated with the estimate: 45%); middle value at least 1.2-fold (0.09 log units) from the limit.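

Within the data shown here, replacing 2,4-dinitrophenyl with 2,4,6-trimethylphenyl on the aromatic nitrogen gives an at least 2.0-fold higher number from compound 2 to compound 3 (0.32 log units; beyond the scatter) in this assay and leaves compound 2 as the only one of the three compounds with a number. The 2-chlorophenyl of compound 1 and the 2,4,6-trimethylphenyl of compound 3 both end at a limit of the assay, so the step between them cannot be read. The step from compound 2 is therefore only a lower bound, and its true size is not shown: the limit of > 50000 nM in this assay, at which 2 of the 3 values shown sit.

The compounds shown do not tell whether both nitro groups are needed for compound 2 to give a number. As far as these compounds go, it also remains open whether 4-nitrophenyl or 4-aminophenyl on this nitrogen would give a number in this assay and how it would stand against compound 2.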